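A few compounds are considered here, and "the series" means these few. Any claim that something is new, unique, unknown or untested is made for them only; others in the source may bear on it.

Measured compounds:
compound 1 `CCc1ccc(NS(=O)(=O)c2ccc(N3CCNC3=O)cc2)cc1` — 660 nM
compound 2 `O=C1NCCN1c1ccc(S(=O)(=O)Nc2ccc(F)c(F)c2)cc1` — 350 nM
compound 3 `Cc1ccc(NS(=O)(=O)c2ccc(N3CCNC3=O)cc2)c(C)c1` — 180 nM

All three were tested in a functional assay on HT-29 cells (Homo sapiens) for antiproliferative activity, read by sulforhodamine B assay, with a stated time of 48 h; a higher number here means a weaker inhibitor, a lower number a stronger inhibitor. Compound 1 gives the highest number of the three. Its nearest neighbour is compound 2, a 1.9-fold lower number from compound 1 to compound 2 (0.28 log units; within the scatter); its furthest is compound 3, a 3.7-fold lower number from compound 1 to compound 3 (0.56 log units; beyond the scatter). Between the other two the step is a 1.9-fold lower number from compound 2 to compound 3 (0.29 log units; within the scatter).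

Compound 4 is `CCCCCc1ccc(NS(=O)(=O)c2ccc(N3CCNC3=O)cc2)cc1`. For the measured compounds named here, its only difference from compound 1 is propyl in place of hydrogen on a saturated chain carbon, two bonds along the chain from an aromatic carbon; seen from the ring, the chain grows from ethyl to pentyl, while the shared core of compound 1 stays as it is.

Going by the values given here, no measured step lengthens a chain. Both steps away from compound 1 exchange the whole aryl group on the sulfonamide nitrogen for a differently substituted ring, and both lower the number, one within the scatter and one modestly beyond it. They therefore say little about a longer chain, and no direction can be read from them with confidence. Compound 4 is estimated to give 500 nM, with a range from 150 nM to 1500 nM. For compound 4 this means an expected step of a 1.3-fold lower number from compound 1 to compound 4 (0.12 log units; within the scatter), a change expected to stay within the scatter.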

Compound 4, half-maximal inhibitory concentration: 990 nM
For compound 4 the middle estimate is 2.0-fold (0.30 log units) below the measured one; the measured number falls inside the stated range.
By their numbers in this assay, from the lowest: compounds 3, 2, 1 and 4 (each within the scatter of the next, the first and the last beyond it).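

In this assay growing the chain from ethyl to pentyl gives a 1.5-fold higher number from compound 1 to compound 4 (0.18 log units; within the scatter) and so compound 1 and compound 4 cannot be told apart by this read-out. The earlier steps shown here each exchanged the whole aryl group on the sulfonamide nitrogen, whereas this one changes only the length of the chain and leaves the shared core of compound 1 as it is. It shows that adding propyl at this saturated chain carbon, two bonds along the chain from an aromatic carbon, brings no change beyond the usual scatter, at least up to pentyl. No measurement is available here that could explain this result.

With only ethyl and pentyl to compare, a single step cannot show whether the number stays level along the whole series, and propyl, butyl or a longer chain such as octyl could still behave differently. As far as these compounds go, it also remains open whether this place accepts more than plain carbon chains, for example a chain ending in an amine, a hydroxyl group or a carboxylic acid.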